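This account rests on a few compounds, and the source may have more. Where it says the series, first, only, none or still open, it means among the compounds named here.

Compound 2 `CC1(C)c2ccc(N)cc2[C@@H](n2ccccc2=O)[C@@H]1O` is the amino member of a pair that shares its core with compound 1 `CCc1ccc2c(c1)[C@@H](n1ccccc1=O)[C@H](O)C2(C)C`. In a functional assay (trachea) for inhibition, with Cavia porcellus as the target (a higher number here means a weaker inhibitor, a lower number a stronger inhibitor), compound 1 gives 2170 nM. Compound 2 gives > 20000 nM in this assay, which is a limit of the assay and not a number. Its position on the numbers shown is therefore (the limit of > 20000 nM in this assay, at which 1 of the 2 values shown sits). The next analogue, compound 3 `CC1(C)c2ccc(C#N)cc2[C@@H](n2ccccc2=O)[C@@H]1O`, carries cyano in place of amino on an aromatic carbon, on a six-membered aromatic ring of carbon only: cyano in place of amino on an aromatic carbon. Among the compounds with values here, only one measured step bears on this change, amino in place of ethyl on an aromatic carbon, which gave an at least 9.2-fold higher number from compound 1 to compound 2 (0.96 log units; beyond the scatter). Within the data shown here, that step replaced ethyl with the same amino group that now leaves, and no cyano compound has yet been measured on this core. With amino gone, a clear move towards a lower number in this assay is expected, returning to about the level of compound 1 at 2170 nM or somewhat past it. The expected change is an at least 20-fold lower number from compound 2 to compound 3 (1.30 log units; beyond the scatter), towards a stronger inhibitor. For compound 3 the estimated value is 1000 nM, with an expected range from 150 nM to 7000 nM.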

Compound 3, half-maximal inhibitory concentration: 1940 nM
Beside the measured number, compound 3's estimate is 1.9-fold (0.29 log units) below it; measured number inside the range.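

In this assay, this position on the aromatic carbon now tolerates two different groups at one level, with amino the only one that stands apart: cyano in place of amino gives an at least 10-fold lower number from compound 2 to compound 3 (1.01 log units; beyond the scatter), while cyano in place of ethyl gives a 1.1-fold lower number from compound 1 to compound 3 (0.05 log units; within the scatter). The second step lies within the scatter, so the earlier loss on going from ethyl to amino is now recovered by a group other than ethyl, and the two groups cannot be told apart in this assay, even though cyano has a triple bond and ethyl does not. Compound 2 remains a limit of the assay and not a number, so the size of both steps that involve it is only a bound: the limit of > 20000 nM in this assay, at which 1 of the 3 values shown sits.

The compounds shown leave open how far compound 2 really lies from the other two, and whether any group at this position reaches a clearly lower number than ethyl and cyano do. They also leave open whether a hydroxyl, a methylamino group or a carboxylic acid here would behave like amino or like cyano.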